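The source may hold more compounds than are shown below. What is called first, only, known or untested is meant among the compounds shown, and "the series" means these compounds.

Three compounds have been measured in a functional assay on HT-29 cells (Homo sapiens) for antiproliferative activity, read by MTT assay, with a stated time of 72 h; on this read-out lower numbers stand for stronger inhibition and higher numbers for weaker inhibition:
compound 1, `CNC(=O)c1cc(Oc2ccc(NC(=O)c3cc4cccnc4n(-c4ccc(Br)cc4)c3=O)cc2)ccn1`, gives 1180 nM;
compound 2, `CNC(=O)c1cc(Oc2ccc(NC(=O)c3cc4cccnc4n(-c4ccc(Br)cc4F)c3=O)cc2)ccn1`, gives 1950 nM;
compound 3, `CCNC(=O)c1cc(Oc2ccc(NC(=O)c3cc4cccnc4n(-c4ccccc4)c3=O)cc2)ccn1`, gives 220 nM.

Compound 1 and compound 2 differ in one place, (fluoro in place of hydrogen on an aromatic carbon). That change gave a 1.7-fold higher number from compound 1 to compound 2 (0.22 log units; within the scatter), so the two values are not set apart from each other. Compound 3 has the lowest number of the three; how its core differs from the core of compound 1 is not broken down here, but its steps to compound 1 and to compound 2 both lie beyond the scatter.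

Compound 4, `CCNC(=O)c1cc(Oc2ccc(NC(=O)c3cc4cccnc4n(-c4ccccc4F)c3=O)cc2)ccn1`, has not yet been measured. It differs from compound 3 in fluoro in place of hydrogen on an aromatic carbon. This is the same kind of change as that from compound 1 to compound 2, though not the same: there the place was also meta to a bromo group, and for compound 4 that is not so. The earlier step was a 1.7-fold higher number from compound 1 to compound 2 (0.22 log units; within the scatter). On that basis, for compound 4 a step of similar size is expected, a 1.6-fold higher number from compound 3 to compound 4 (0.20 log units; within the scatter). Compound 4 is therefore estimated at 350 nM, with a likely range from 150 nM to 800 nM.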

Compound 4, half-maximal inhibitory concentration: 260 nM
For compound 4 the middle estimate is 1.3-fold (0.13 log units) above the measured one; low and high end bracket the measured number.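

In this assay, putting fluoro in place of hydrogen, which turns phenyl into 2-fluorophenyl, gave a 1.2-fold higher number from compound 3 to compound 4 (0.07 log units; within the scatter), so the values of these two compounds are not set apart. Set beside the earlier step, the change reads alike on both cores: the same change on two cores in this assay, a 1.7-fold higher number (0.22 log units; within the scatter) from compound 1 to compound 2 and a 1.2-fold higher number (0.07 log units; within the scatter) from compound 3 to compound 4, 1.4-fold (0.15 log units) apart, within the scatter of two such steps. For the compounds shown here, this shows that in these two pairs the step stayed small on either core, but it rests on only two pairs, and both steps are too small to be told from no change at all, so it does not show that fluoro would stay this quiet on other cores or at other places on the ring.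

The compounds shown leave open whether a larger group, such as chloro or methoxy, would also stay within the scatter in the place fluoro holds in compound 4. They also leave open whether an amine or a carboxylic acid there would move the number clearly in either direction.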